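Swapping a pyrrolidine for an aminocyclohexylamine at the aryl position

A few compounds are considered here, and "the series" means these few. Any claim that something is new, unique, unknown or untested is made for them only; others in the source may bear on it.

Measured compounds:
compound 1, `CN(C)[C@@H]1CCN(c2cccc3c2C[C@H](CN(C)[C@H]2CCCc4cccnc42)NC3)C1`, 10.4 nM
compound 2, `CN1CCN(Nc2cccc3c2C[C@@H](CN(C)[C@H]2CCCc4cccnc42)NC3)CC1`, 47.4 nM

In a functional assay on CCRF-CEM cells for antagonist activity at C-X-C chemokine receptor type 4 (Homo sapiens), read by calcium flux, with stated times of 25 min and 90 s (on this read-out higher numbers stand for weaker inhibition and lower numbers for stronger inhibition), compound 1 gives the lowest number of the two, and compound 2 gives a number well beyond the scatter above it. Compound 3, `CN(C[C@H]1Cc2c(cccc2N[C@H]2CC[C@H](N)CC2)CN1)[C@H]1CCCc2cccnc21`, keeps every atom of compound 1 but joins them differently: (4-aminocyclohexyl)amino in place of 3-(dimethylamino)pyrrolidin-1-yl on an aromatic carbon. Among the measured compounds shown here, no measured pair shows this exact change, so the expectation rests on the two values alone. The step from a 2.4-fold higher number from compound 1 to compound 3 (0.38 log units; beyond the scatter) is expected to be a modest weakening, as compound 2 with its amino-linked ring gives 47.4 nM. Compound 3 is estimated at 25 nM, likely between 8 nM and 80 nM.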

Compound 3, half-maximal inhibitory concentration: 755 nM
Beside the measured number, compound 3's estimate is 30-fold (1.48 log units) below it, and the stated range ends below it.
By their numbers in this assay, from the lowest: compound 1; then compound 2; then compound 3.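

In this assay the swap gives a 73-fold higher number from compound 1 to compound 3 (1.86 log units; beyond the scatter) and so shows that this aromatic carbon is highly sensitive to how the same atoms are joined. Keeping the heavy-atom count is no safeguard here, as (4-aminocyclohexyl)amino and 3-(dimethylamino)pyrrolidin-1-yl both show. No measurement here explains the loss. The compounds shown leave open whether the carbon-only ring, the linking amine or the free amine accounts for the step. A 4-(dimethylamino)piperidin-1-yl group would be one way to separate these features.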